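Changing the Attached Ring on Compound 1

This account rests on a few compounds, and the source may have more. Where it says the series, first, only, none or still open, it means among the compounds named here.

Compound 1 `Nc1ncn(CCC2(N)OC(=O)C(OCc3ccccc3)=C2OCc2ccccc2)c(=O)n1` carries one six-membered aromatic ring with 3 hetero atoms on a saturated chain. In a functional assay on MIA PaCa-2 cells (Homo sapiens) for inhibition, read by MTT assay, with a stated time of 72 h (on this read-out lower numbers stand for stronger inhibition and higher numbers for weaker inhibition), compound 1 gives only a limit, > 100000 nM, and no number. Compound 3 `Nc1ccn(C[C@H](O)[C@H]2OC(=O)C(OCc3ccccc3)=C2OCc2ccccc2)c(=O)n1` also stops at a limit in this assay, > 100000 nM. Compound 2 `O=C1O/C(=C\Cn2ncc(=O)[nH]c2=O)C(OCc2ccccc2)=C1OCc1ccccc1` is the only one of the three measured compounds to give a number in this assay, 20400 nM. Compound 1 therefore sits at the limit of > 100000 nM in this assay, at which 2 of the 3 values shown sit, and on these figures it cannot be told apart from compound 3.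

Compound 4 `Nc1ccn(CCC2(N)OC(=O)C(OCc3ccccc3)=C2OCc2ccccc2)c(=O)n1` differs from compound 1 in one place: a group of 8 heavy atoms (4 carbon, 3 nitrogen, 1 oxygen; one six-membered aromatic ring with 2 hetero atoms) in place of a group of 8 heavy atoms (3 carbon, 4 nitrogen, 1 oxygen; one six-membered aromatic ring with 3 hetero atoms), on a saturated chain carbon, two bonds along the chain from a saturated ring carbon. For the measured compounds named here, no measured pair shows this exact change, so the expectation rests on what the three measured compounds show. Compound 3, which also carries the six-membered aromatic ring with 2 hetero atoms, reaches only its limit in this assay, > 100000 nM. Compound 4 is therefore expected to remain at the limit, with an estimate of 100000 nM in a range from 30000 nM to 300000 nM. The step expected in this assay is a number no higher from compound 1 to compound 4 (the limit leaves the size open), that is, nothing beyond the usual scatter.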

Compound 4, half-maximal inhibitory concentration: > 100000 nM
Compound 4: a limit, no number; the forecaster's own chance of this, stated with the estimate: 70%; the middle value sits exactly at the limit.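

For the compounds shown here, compound 1 and compound 4 both stop at a limit in this assay and give no number, so no step between them can be read. The compounds shown leave open how strongly each of the two inhibits, and so whether changing the attached ring changes anything.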